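The source may report more compounds than this note shows. Statements on the series, on what has been measured and on what is new or still open speak of the compounds shown alone.

Measured so far in a functional assay on MIA PaCa-2 cells (Homo sapiens) for antiproliferative activity, read by sulforhodamine B assay, with a stated time of 48 h; a higher number here means a weaker inhibitor of growth, a lower number a stronger inhibitor of growth: compound 1 `COc1ccc(Cn2cc(CNC(=O)c3cn(-c4ccccc4)nc3-c3ccccc3)nn2)cc1OC` gives 8200 nM; compound 2 `COc1cc(Cn2cc(CNC(=O)c3cn(-c4ccccc4)nc3-c3ccccc3)nn2)cc(OC)c1` gives 190 nM; compound 3 `COc1cc(Cn2cc(CNC(=O)c3cn(-c4ccccc4)nc3-c3ccccc3)nn2)cc(OC)c1OC` gives 1000 nM.

Compound 1 stands at the highest number of the three: a 43-fold lower number from compound 1 to compound 2 (1.64 log units; beyond the scatter) and an 8.2-fold lower number from compound 1 to compound 3 (0.91 log units; beyond the scatter), with a 5.3-fold higher number from compound 2 to compound 3 (0.72 log units; beyond the scatter) between the other two. Compound 4 `COc1ccc(Cn2cc(CNC(=O)c3cn(-c4ccccc4)nc3-c3ccc(F)cc3)nn2)cc1OC` differs from compound 1 by fluoro in place of hydrogen on an aromatic carbon, para to a large group; cut one bond further out, the change reads phenyl to 4-fluorophenyl. Among the measured compounds shown here, none of the measured steps touches that ring: all three move methoxy groups on the benzyl ring and so give no direct guide. With nothing bearing on it, the expected step is no change at the digits printed from compound 1 to compound 4 (within the scatter), within the usual scatter. Compound 4 is therefore estimated at 8200 nM, in the range 3500 nM to 20000 nM.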

Compound 4, concentration for 50% growth inhibition: > 100000 nM
Compound 4: a limit, no number; the forecaster's own chance of this, stated with the estimate: 5%; at least 12-fold (1.08 log units) between middle value and limit.
By their numbers in this assay, from the lowest: compound 2; then compound 3; then compound 1. At a limit, above all of these: compound 4.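

In this assay, the change from phenyl to 4-fluorophenyl gives an at least 12-fold higher number from compound 1 to compound 4 (1.08 log units; beyond the scatter). Among the compounds shown here, this ring, untouched by the earlier steps, is therefore sensitive to substitution in the compound 1 series: a single fluoro in place of hydrogen, para to a large group, matters as much as the methoxy changes on the benzyl ring. The reading for compound 4 is a limit and not a number: the limit of > 100000 nM in this assay, at which 1 of the 4 values shown sits.

Going by these compounds, whether fluoro has the same effect with the 3,5-dimethoxyphenyl group of compound 2 remains open. So does how chloro, methoxy or an amine would read at this place.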